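Cyclopentylmethyl to propyl: an expected step for compound 4

The source may report more compounds than this note shows. Statements on the series, on what has been measured and on what is new or still open speak of the compounds shown alone.

In an ADME assay on A549 cells (Homo sapiens) for cytotoxicity, read by LDH release, with a stated time of 15 h (on this read-out higher numbers stand for lower toxicity in this test and lower numbers for higher toxicity in this test), compound 1 (`O=C(Nc1ccc(N2CCCC2)cc1Cl)c1cc(Cl)ccc1O`) is reported as "not determined" (no result reported) and offers no number for comparison. Compound 2 (`CC1(Nc2ccc(NC(=O)c3cc(Cl)ccc3O)c(Cl)c2)CCCCC1`) gives 86500 nM and compound 3 (`O=C(Nc1ccc(NCC2CCCC2)cc1Cl)c1cc(Cl)ccc1O`) gives 141000 nM in the same test, so compound 3 stands level with compound 2 within the scatter. Compound 4 (`CCCNc1ccc(NC(=O)c2cc(Cl)ccc2O)c(Cl)c1`) differs from compound 3 as follows: ethyl in place of cyclopentyl on a saturated chain carbon bound to a nitrogen on an aromatic ring and thus cyclopentylmethyl gives way to propyl. Within the data shown here, only one measured step bears on this substituent, and it is small: a 1.6-fold higher number from compound 2 to compound 3 (0.21 log units; within the scatter) for a different exchange on the same nitrogen. On that basis no step beyond the scatter is expected in this assay here. The estimate amounts to a 1.2-fold lower number from compound 3 to compound 4 (0.07 log units; within the scatter) as the expected step. The expected value for compound 4 is 120000 nM (estimated range 50000 nM to 290000 nM).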

Compound 4, half-maximal cytotoxic concentration: 69700 nM
The estimate for compound 4 lay 1.7-fold (0.24 log units) above the measured number; measured number inside the range.
By their numbers in this assay, from the lowest: compounds 4, 2 and 3 (each within the scatter of the next, the first and the last beyond it).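

In this assay, ethyl in place of cyclopentyl gives the only step shown on this nitrogen substituent that lies beyond the scatter (a 2.0-fold lower number from compound 3 to compound 4 (0.31 log units; beyond the scatter)), and that step is modest. Propyl in place of 1-methylcyclohexyl stays within the scatter (a 1.2-fold lower number from compound 2 to compound 4 (0.09 log units; within the scatter)), so only the two end compounds of the series stand apart. Nothing given here accounts for the difference between cyclopentylmethyl and propyl.

On these data alone, whether a longer chain or a carboxylic acid in place of the ethyl would shift the number in this assay remains open.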